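Quinoxaline-diamine series: thioether in place of benzylamine

This account rests on a few compounds, and the source may have more. Where it says the series, first, only, none or still open, it means among the compounds named here.

In a functional assay on UACC-62 cells (Homo sapiens) for inhibition, read by sulforhodamine B assay, with a stated time of 48 h (on this read-out lower numbers stand for higher toxicity in this test and higher numbers for lower toxicity in this test), compound 2 `Nc1cc(N)c2nc(-c3ccccc3)c(NCc3ccc(F)cc3)nc2c1` gives 56200 nM, the lowest of the two plain numbers shown, and its nearest neighbour is compound 3 `COc1ccc(CNc2nc3cc(N)cc(N)c3nc2-c2ccccc2)cc1`, which gives 58900 nM in this assay. The change a 1.0-fold higher number from compound 2 to compound 3 (0.02 log units; within the scatter) lies within the scatter. For compound 1 `Nc1cc(N)c2nc(-c3ccccc3)c(Oc3ccc(Cl)c(Cl)c3)nc2c1` this assay reports a limit, < 100000 nM; the step that the limit leaves unreadable from compound 1 to compound 2 therefore cannot be read, as the limit of < 100000 nM in this assay, at which 1 of the 3 values shown sits, shows.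

Compound 4 `COc1ccc(Sc2nc3cc(N)cc(N)c3nc2-c2ccccc2)cc1` is not yet measured. Relative to compound 2 it carries (4-methoxyphenyl)sulfanyl in place of (4-fluorobenzyl)amino on an aromatic carbon. Within the data shown here, no measured step exchanges the linking group in this way: the one step with a comparable exchange of the side group starts from the limit of compound 1 and has no readable size, and the step from compound 2 to compound 3 alters only the substituent on the carbon ring and stays within the scatter. The expected step of a 1.1-fold higher number from compound 2 to compound 4 (0.03 log units; within the scatter) is therefore set at no change beyond the scatter, with a wide range because the limit of < 100000 nM in this assay, at which 1 of the 3 values shown sits, on the aryl ether of compound 1 leaves the effect of a non-nitrogen linker open. Compound 4 is estimated at 60000 nM in this assay, between 25000 nM and 140000 nM.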

Compound 4, concentration lethal to 50% of the cells: < 100000 nM
Compound 4: no number, only a limit; the forecaster's own chance of this, stated with the estimate: 25%; the middle value does not contradict the limit.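

In this assay compound 4 gives < 100000 nM, which is a limit and not a number, so no step from compound 2 or compound 1 to compound 4 can be read: the limit of < 100000 nM in this assay, at which 2 of the 4 values shown sit.

On these data alone, whether (4-methoxyphenyl)sulfanyl or 3,4-dichlorophenoxy in place of (4-fluorobenzyl)amino shifts the read-out beyond the scatter remains open.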